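The compounds below may be only part of what the source reports. "The series", "measured", "known", "first", "only" and "open" are said of these compounds alone.

Working notes, fused-core series

Of the compounds shown here, three have been measured in a functional assay on HOP-92 cells (Homo sapiens) for cytotoxicity, read by sulforhodamine B assay, with a stated time of 48 h; a higher number here means a weaker inhibitor of growth, a lower number a stronger inhibitor of growth. Compound 1 `ClCc1ccccc1Cn1cnc2c(Cl)nc(Cl)nc21` gives 970 nM in this assay. Compound 2 `ClCc1ccccc1Cn1cnc2c(Cl)ncnc21` gives 4260 nM in this assay. Compound 3 `ClCc1ccccc1Cn1cnc2ncnc(Cl)c21` gives 12900 nM in this assay, the highest of the three numbers; compound 2 stands nearest to it and compound 1 furthest, both gaps beyond the scatter.

Among the measured compounds shown here, the only single-point step within the measured set is a 4.4-fold lower number from compound 2 to compound 1 (0.64 log units; beyond the scatter), the change being (chloro in place of hydrogen on an aromatic carbon). Compound 2 and compound 3 have the same atoms joined differently; the difference between the two cores is not broken down here, so only their two values in this assay can be set side by side.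

Compound 4 `ClCc1ccccc1Cn1cnc2nc(Cl)nc(Cl)c21` has not yet been measured in this assay. It differs from compound 3 by chloro in place of hydrogen on an aromatic carbon, which is the same change, in a place described in identical words, as that from compound 2 to compound 1; the change appears in two pairs in all. The step is expected to carry over: compound 4 is expected to give about 3000 nM in this assay, within a range from 1300 nM to 7000 nM. For the measured compounds named here, the expected step of a 4.3-fold lower number from compound 3 to compound 4 (0.63 log units; beyond the scatter) rests on the single earlier step of a 4.4-fold lower number from compound 2 to compound 1 (0.64 log units; beyond the scatter), which was seen on a different core, so the estimate is held with a wide margin.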

Compound 4, concentration for total growth inhibition: 2810 nM
Beside the measured number, compound 4's estimate is 1.1-fold (0.03 log units) above it; the measured number falls inside the stated range.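

In this assay, chloro in place of hydrogen on an aromatic carbon gives a 4.6-fold lower number from compound 3 to compound 4 (0.66 log units; beyond the scatter), and this step agrees with the earlier one: the same change on two cores in this assay, a 4.4-fold lower number (0.64 log units; beyond the scatter) from compound 2 to compound 1 and a 4.6-fold lower number (0.66 log units; beyond the scatter) from compound 3 to compound 4, 1.0-fold (0.02 log units) apart, within the scatter of two such steps

Across these two cores, the change therefore carries over with its size intact, even though the cores are joined differently, and no compound shown goes against this. Among the compounds shown here, this rests on only two pairs, with one group entering at a place described in the same words in both, and read in a single assay, so it sets no rule for any further core and gives no reason why the size holds.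

Still open, as far as these compounds go, is whether another group at the same place, such as an amine, a methoxy group or a longer chain, would give a step of similar size on both cores. Also open, from the compounds shown here alone, is what happens to these numbers when the chloromethyl group carried by all four compounds gives way to a hydroxymethyl group or a plain methyl group, and whether the agreement between the two steps would survive on such compounds.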